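Swapping formyl for a longer ester on the chain

The source may hold more compounds than are shown below. What is called first, only, known or untested is meant among the compounds shown, and "the series" means these compounds.

In a functional assay on Raji cells (Homo sapiens) for cytotoxicity, with a stated time of 72 h (a lower number here means that less compound is needed, a higher number that more compound is needed for the effect), compound 1 `C=C[C@@](C)(/C=C/c1ccc(O)cc1)CCC1OC1(C)C` gives > 22500 nM as a limit. Compound 2 `C=C[C@@](C)(/C=C/c1ccc(O)cc1)CC/C=C(\C)C=O` gives > 26000 nM as a limit too, so its standing is known only as a limit. Compound 3 `C=C[C@@](C)(/C=C/c1ccc(O)cc1)CC/C=C(C)/C=C/C(=O)OCC` carries 2-(ethoxycarbonyl)ethenyl in place of formyl on a double-bonded chain carbon bound to a double-bonded chain carbon and a saturated chain carbon. Among the measured compounds shown here, the one measured step bearing on this is a step that the two limits leave unreadable from compound 1 to compound 2 and offers no size to carry over, so no step beyond the scatter is expected in this assay on this evidence. The expected step is an at least 1.0-fold lower number from compound 2 to compound 3 (0.01 log units; that floor lies within the scatter) as estimated here. Compound 3 is estimated at 25000 nM with 9000 nM to 50000 nM as its expected range.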

Compound 3, half-maximal effective concentration: > 26000 nM
Compound 3: only a limit was reported (the forecaster's own chance of this, stated with the estimate: 70%); at least 1.0-fold (0.01 log units) between middle value and limit.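

Compound 2 and compound 3 are both reported only as limits, so no step can be read between them: the limit of > 26000 nM in this assay, at which 2 of the 3 values shown sit. The compounds shown leave open whether 2-(ethoxycarbonyl)ethenyl in place of formyl changes the cytotoxic concentration at all.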